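The source may report more compounds than this note shows. Statements on the series, on what has been measured and on what is new or still open speak of the compounds shown alone.

Measured in a functional assay on MDA-MB-231 cells (Homo sapiens) for antiproliferative activity, read by MTT assay, with a stated time of 72 h; a lower number here means a stronger inhibitor, a higher number a weaker inhibitor:
Compound 1 `O=C(CCc1cccc2c1B(O)OC2)Nc1ccc(Br)cc1`: 5300 nM
Compound 2 `O=C(CCc1cccc2c1B(O)OC2)Nc1ccc(I)cc1`: 33000 nM
Compound 3 `Cc1ccc(NC(=O)CCc2cccc3c2B(O)OC3)cc1`: 1100 nM

Among these three, compound 3 has the lowest number, at 1100 nM, which makes it the most potent of this small set. The smallest gap to it is a 4.8-fold lower number from compound 1 to compound 3 (0.68 log units; beyond the scatter), and the widest is a 30-fold lower number from compound 2 to compound 3 (1.48 log units; beyond the scatter).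

Compound 4 `COc1ccc(NC(=O)CCc2cccc3c2B(O)OC3)cc1` is still unmeasured and differs from compound 3 in a single group: methoxy in place of methyl on an aromatic carbon. This is methoxy in place of methyl on an aromatic carbon, para to a large group.

Going by the values given here, no measured compound carries methoxy, so the guidance is indirect. The three measured steps each exchange one group on that same aromatic carbon. Besides the two above, there is a 6.2-fold higher number from compound 1 to compound 2 (0.79 log units; beyond the scatter). Such swaps have therefore moved the number in this assay by modest to large amounts, so a change of one group here cannot be assumed to be silent. Compound 3 gives 1100 nM, and compound 1 and compound 2 both give higher numbers, so a modest move towards a higher number is expected, though a step within the scatter remains possible.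

The expected step is a 2.0-fold higher number from compound 3 to compound 4 (0.30 log units; within the scatter). For compound 4 the estimated value is 2200 nM, with an expected range from 600 nM to 8000 nM.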

Compound 4, half-maximal inhibitory concentration: 850 nM
Beside the measured number, compound 4's estimate is 2.6-fold (0.41 log units) above it, and the stated range covers the measured number.
By their numbers in this assay, from the lowest: compounds 4 and 3 (each within the scatter of the next); then compound 1; then compound 2.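

In this assay, going by these compounds alone, the exchange of methyl for methoxy is the first step at this position that stays within the scatter: a 1.3-fold lower number from compound 3 to compound 4 (0.11 log units; within the scatter). Bringing in an oxygen atom, a hydrogen-bond acceptor and one more heavy atom on this aromatic carbon therefore leaves compound 4 indistinguishable from compound 3, which shows that this position does not respond strongly to every exchange. Methoxy stands clearly apart from both halogens, with a 6.2-fold lower number from compound 1 to compound 4 (0.79 log units; beyond the scatter) and a 39-fold lower number from compound 2 to compound 4 (1.59 log units; beyond the scatter), so among these four compounds methyl and methoxy sit together and bromo and iodo lie at higher numbers, with no compound going against that split.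

No evidence is available to explain why these four groups fall as they do. Also open, as far as these compounds go, is whether an amine, a carboxylic acid or a longer chain such as ethoxy on this same carbon would stay with methyl and methoxy or lie nearer bromo and iodo, and whether methoxy would give a similar number on another carbon of that ring.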